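This account rests on a few compounds, and the source may have more. Where it says the series, first, only, none or still open, it means among the compounds named here.

Measured compounds:
- compound 1, `NN1C(=O)/C(=C/c2c[nH]c3ccccc23)SC1=S`; in a functional assay on HL-60 cells (Homo sapiens) for cytotoxicity, read by MTT assay, with a stated time of 72 h (a higher number here means a weaker inhibitor, a lower number a stronger inhibitor), compound 1 gives 3610 nM
- compound 2, `O=C1NC(=S)S/C1=C\c1c[nH]c2ccccc12`; compound 2 gives > 50000 nM in this assay, which is a limit of the assay rather than a number
- compound 3, `O=C1NC(=O)/C(=C/c2c[nH]c3ccccc23)S1`; compound 3 gives 12800 nM in this assay

Compound 2 therefore stands at the weak end of what has been measured: its value is the limit (the limit of > 50000 nM in this assay, at which 1 of the 3 values shown sits), and of the three compounds it is the only one that reaches it. Among the measured compounds shown here, the one measured step that involves compound 2 is an at least 13-fold higher number from compound 1 to compound 2 (1.14 log units; beyond the scatter), where hydrogen replaces an amino group on the ring nitrogen; it is large and well beyond the scatter. For the measured compounds named here, compound 3 carries a carbonyl where compound 2 carries a thiocarbonyl, but no step between those two has been worked out, so only their two values stand side by side.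

Compound 4, `O=C1NC(=S)S/C1=C\c1c[nH]c2ccc(Br)cc12`, differs from compound 2 in a single place: bromo in place of hydrogen on an aromatic carbon. Going by the values given here, none of the measured steps touches this ring position or a bromo group, so no measured step gives guidance on the size or direction of the change. With nothing pointing either way, the expected step of a number no higher from compound 2 to compound 4 (the limit leaves the size open) in this assay is none beyond the scatter. Compound 4 is accordingly estimated at 50000 nM, within a range from 15000 nM to 200000 nM, and it is expected that the assay may again report only a limit.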

Compound 4, half-maximal inhibitory concentration: > 50000 nM
Compound 4 was reported as a limit; the forecaster's own chance of this, stated with the estimate: 65%; the middle value lies on the limit itself.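

Compound 2 and compound 4 both end at a limit of the assay rather than at a number, so the step between them, bromo in place of hydrogen on an aromatic carbon, cannot be read: the limit of > 50000 nM in this assay, at which 2 of the 4 values shown sit. The compounds shown leave open what a bromo group at this place would do in a compound with a measurable value, such as compound 1 or compound 3.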